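The compounds below may be only part of what the source reports. "The series", "measured", "known", "first", "only" and "open" are said of these compounds alone.

Measured so far in a physicochemical assay for solubility, using the shake flask method, in phosphate buffer, with a stated time of 24 h, at 25 degrees C, at pH 6.8; a lower number here means a less soluble compound, a higher number a more soluble compound:
Compound 1 `Cc1nc(O)c2c[nH]nc2n1`: 1480 ug/mL
Compound 2 `CCc1nc(O)c2c[nH]nc2n1`: 710 ug/mL

Of these two compounds, compound 2 has the lower number, at 710 ug/mL. The next compound, compound 3 `CCCc1nc(O)c2c[nH]nc2n1`, extends ethyl to propyl. The change is methyl in place of hydrogen on a saturated chain carbon, two bonds along the chain from an aromatic carbon.

Among the measured compounds shown here, only one measured step bears on this. It is the same kind of change, made on a saturated chain carbon bound to an aromatic carbon, and it was modest: a 2.1-fold lower number from compound 1 to compound 2 (0.32 log units; beyond the scatter). With this single step as the guide, a drop of similar size is expected in this assay, though one step cannot establish a trend. The expected change is a 2.0-fold lower number from compound 2 to compound 3 (0.31 log units; beyond the scatter). For compound 3 the estimated value is 350 ug/mL, with an expected range of 160 ug/mL to 760 ug/mL.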

Compound 3, solubility: 2070 ug/mL
Beside the measured number, compound 3's estimate is 5.9-fold (0.77 log units) below it, outside the stated range (above it).
By their numbers in this assay, from the lowest: compound 2; then compounds 1 and 3 (each within the scatter of the next).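

In this assay the same change, methyl in place of hydrogen, on a saturated chain carbon, two bonds along the chain from an aromatic carbon, gave a 2.9-fold higher number from compound 2 to compound 3 (0.46 log units; beyond the scatter) while on a saturated chain carbon bound to an aromatic carbon it had given a 2.1-fold lower number from compound 1 to compound 2 (0.32 log units; beyond the scatter) and so the change has no single direction along this chain. Taken end to end, the two changes together give a 1.4-fold higher number from compound 1 to compound 3 (0.15 log units; within the scatter) so the numbers do not fall steadily as the chain grows, and compound 2 alone stands apart. No supporting measurement accounts for this turn.

The compounds shown leave open whether a longer chain such as butyl would continue the rise or turn it back. They also leave open how a branched isopropyl group, or an amine at the chain end, would read here.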